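A few compounds are considered here, and "the series" means these few. Any claim that something is new, unique, unknown or untested is made for them only; others in the source may bear on it.

Compound 2 `CNC(=O)N1CCCc2ccc(NC(=O)c3ccc(-c4cnn(C)c4)cc3)cc21` gives 94.4% in a functional assay on MV4-11 cells (Homo sapiens) for antiproliferative activity, with a stated time of 6 days, tested at 6.25 uM (a higher number here means a stronger effect of the compound at the concentration tested, a lower number a weaker effect), the highest of the three measured numbers. Compound 1 `CNC(=O)N1CCCc2ccc(NC(=O)c3cccc(-c4ccccc4)c3)cc21` gives 1.39%, and compound 3 `CNC(=O)N1CCCc2ccc(NC(=O)c3cccc(-c4cnn(S(C)(=O)=O)c4)c3)cc21` gives 18%; both differences from compound 2 lie beyond the scatter. The step from compound 1 to compound 3 was a number 16.6 percentage points higher from compound 1 to compound 3 (beyond the scatter). Compound 4 `CNC(=O)N1CCCc2ccc(NC(=O)c3ccc(-c4cnn(C(C)=O)c4)cc3)cc21` differs from compound 2 by acetyl in place of methyl on an aromatic nitrogen. For the measured compounds named here, no measured step swaps one group for another on the same ring nitrogen, so the only guide is that compound 3, which also carries a group with an oxygen on that nitrogen, sits far below compound 2. A downward step is therefore expected, its size uncertain: a number 34.4 percentage points lower from compound 2 to compound 4 (beyond the scatter). Compound 4 is estimated at 60%, between 20% and 95%.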

Compound 4, a percentage reported as inhibition, at one concentration (the size of the read-out at that concentration, not a potency): 83.8%
The estimate for compound 4 lay 23.8 percentage points below the measured number; low and high end bracket the measured number.
By their numbers in this assay, from the lowest: compound 1; then compound 3; then compound 4; then compound 2.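

Putting acetyl in place of methyl on the aromatic nitrogen gives a number 10.6 percentage points lower from compound 2 to compound 4 (beyond the scatter), so this position tolerates a larger group that carries a carbonyl oxygen, at a modest cost. For the compounds shown here, this is the first change made at this nitrogen with the rest of the molecule held fixed. No available measurement explains the size of this step.

As far as these compounds go, what a longer acyl chain such as butanoyl, or a bare hydrogen, would do on this nitrogen remains open. From the compounds shown here alone, the read-out comes from one concentration, so how far compound 2 and compound 4 differ in potency is also open.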